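The source may hold more compounds than are shown below. What is called first, only, known or untested is meant among the compounds shown, and "the series" means these compounds.

Measured compounds in a functional assay on QGY7701 cells (Homo sapiens) for cytotoxicity, read by MTT assay, with a stated time of 24 h; on this read-out lower numbers stand for stronger inhibition and higher numbers for weaker inhibition:
Compound 1 `C=CC1=C(C(=O)O)C(c2ccc(F)cc2)OC1`: compound 1 gives > 100000 nM, a limit of the assay.
Compound 2 `C=CC1=C(C(=O)O)C(c2ccc(OC)cc2)OC1`: compound 2 gives > 100000 nM, a limit of the assay.
Compound 3 `C=CC1=C(C(=O)NCC(C)C)C(c2ccc(F)cc2)OC1`: compound 3 gives > 100000 nM, a limit of the assay.

Compound 2 stands only at a limit in this assay, as do the two other measured compounds (the limit of > 100000 nM in this assay, at which 3 of the 3 values shown sit). The steps from compound 1 to compound 2 (a step that the two limits leave unreadable from compound 1 to compound 2) and from compound 1 to compound 3 (a step that the two limits leave unreadable from compound 1 to compound 3) are both unreadable, since all three values sit at the same limit.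

Compound 4 `C=CC1=C(C(=O)NC2CCCCC2)C(c2ccc(OC)cc2)OC1` differs from compound 2 by cyclohexylamino in place of hydroxy on a carbonyl carbon. The step that bears most closely on it is the amide change from compound 1 to compound 3, which left both values at the limit; no readable size is available from it. With compound 2 itself at the limit, no direction can be read out, and the expectation is that compound 4 stays near the limit as well, with the step from compound 2 to compound 4 estimated as a step that the limit leaves unreadable from compound 2 to compound 4. Compound 4 is therefore estimated at 150000 nM in this assay, within 40000 nM to 600000 nM.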

Compound 4, half-maximal inhibitory concentration: > 100000 nM
Compound 4: a limit, no number; the forecaster's own chance of this, stated with the estimate: 80%; the middle value is on the limit's open side.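

In this assay compound 4 gives > 100000 nM, a limit of the assay. No step can be read between compound 2 and compound 4, since both sit at the same limit: the limit of > 100000 nM in this assay, at which 4 of the 4 values shown sit.

The compounds shown leave open whether any change on the shared core gives a readable value.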